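This account rests on a few compounds, and the source may have more. Where it says the series, first, only, none or still open, it means among the compounds named here.

In a functional assay on HT-29 cells (Homo sapiens) for antiproliferative activity, read by MTT assay, with a stated time of 72 h (on this read-out lower numbers stand for stronger inhibition and higher numbers for weaker inhibition), compound 1 `C=CC(=O)Nc1nc(-c2ccccc2O)cs1` gives 16200 nM. Compound 2 `C=CC(=O)N(Cc1cc(C)no1)c1nc(-c2ccccc2OC)cs1` returns no number, only a limit of the assay, > 30000 nM. Its true position is therefore unknown, and it offers a ceiling-bound starting point rather than a measured one.

Compound 3 `C=CC(=O)N(Cc1cc(C)no1)c1nc(-c2ccccc2O)cs1` departs from compound 2 by a single change, hydrogen in place of methyl on an oxygen on an aromatic ring, turning 2-methoxyphenyl into 2-hydroxyphenyl. Among the measured compounds shown here, no measured pair in this set isolates that change, so any step size remains an expectation. For the measured compounds named here, the only measured compound bearing 2-hydroxyphenyl, compound 1, gives 16200 nM, and this value anchors the expectation. A modest step towards stronger inhibition in this assay is expected, an at least 2.1-fold lower number from compound 2 to compound 3 (0.33 log units; beyond the scatter). For compound 3 the estimated value is 14000 nM, with an expected range of 5000 nM to 30000 nM.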

Compound 3, half-maximal inhibitory concentration: > 30000 nM
Compound 3: only a limit was reported (the forecaster's own chance of this, stated with the estimate: 30%); middle value at least 2.1-fold (0.33 log units) away from the limit.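

In this assay compound 3 also stops at a limit, > 30000 nM, so the 2-hydroxyphenyl group gives no readable number when the (3-methyl-1,2-oxazol-5-yl)methyl group sits on the amide-type nitrogen. The change from methoxy to hydroxy cannot be read, since both of its ends are limits: the limit of > 30000 nM in this assay, at which 2 of the 3 values shown sit. The pair that shares the 2-hydroxyphenyl group and differs only on that nitrogen gives an at least 1.8-fold higher number from compound 1 to compound 3 (0.26 log units; that floor lies within the scatter), so the added group brings no sign of stronger inhibition, though this floor alone does not establish a loss.

Going by these compounds, how far compound 2 and compound 3 lie past the limit remains open, and so does any effect of the methoxy to hydroxy change in this assay. Also open, on these data alone, is whether a methyl or a 2-aminoethyl group on the amide-type nitrogen would give a measurable value.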